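This account rests on a few compounds, and the source may have more. Where it says the series, first, only, none or still open, it means among the compounds named here.

Values in a functional assay on CAKI-1 cells (Homo sapiens) for antiproliferative activity; on this read-out higher numbers stand for weaker inhibition of growth and lower numbers for stronger inhibition of growth:
- Compound 1 `Cc1cccc(-c2cc(O)c3ccc(C)nc3n2)c1`: 427 nM
- Compound 2 `Oc1cc(-c2ccc3ccccc3c2)nc2ncccc12`: 5620 nM
- Compound 3 `Cc1cc(C)c2c(O)cc(-c3cccc4ccccc34)nc2n1`: 9550 nM

Compound 2 stands within the scatter of compound 3, while compound 1 lies beyond the scatter from it, with the lower number. Compound 4 `Cc1ccnc2nc(-c3ccc4ccccc4c3)cc(O)c12` differs from compound 2 in one place: methyl in place of hydrogen on an aromatic carbon, opposite the ring nitrogen. Within the data shown here, no measured pair shows this change alone. Compound 1 and compound 3 both carry methyl on the core, yet compound 1 gives 427 nM and compound 3 gives 9550 nM, so they set no direction. No step beyond the scatter is therefore expected in this assay. The estimated step of a 1.1-fold lower number from compound 2 to compound 4 (0.05 log units; within the scatter) is small. For compound 4 the expected value is 5000 nM, with an estimated range of 1700 nM to 14000 nM.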

Compound 4, concentration for 50% growth inhibition: 2400 nM
Estimate against measurement, compound 4: 2.1-fold (0.32 log units) above, within the range that was stated.
By their numbers in this assay, from the lowest: compound 1; then compound 4; then compounds 2 and 3 (each within the scatter of the next).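

In this assay, methyl in place of hydrogen on an aromatic carbon, opposite the ring nitrogen, gives a 2.3-fold lower number from compound 2 to compound 4 (0.37 log units; beyond the scatter) and so a modest gain in inhibition of growth. Among these compounds, this is the first comparison here that isolates a single change, and it shows that this position responds to methyl, which the earlier compounds could not show. Nothing measured here explains the step.

From the compounds shown here alone, whether an ethyl group or an amine at this position would go further remains open. So does whether methyl here would have the same effect with the other group carried by compound 1.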